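A few compounds are considered here, and "the series" means these few. Any claim that something is new, unique, unknown or untested is made for them only; others in the source may bear on it.

Three amides sharing one core were tested in an ADME assay on Vero cells (Chlorocebus sabaeus) for cytotoxicity, read by reporter gene assay, with a stated time of 4 days; on this read-out lower numbers stand for stronger inhibition and higher numbers for weaker inhibition. Compound 1 `CCCCCCCC(=O)NCC(C)(C)CC1=C(O)C(=O)c2ccccc2C1=O` gives 18400 nM. Compound 2 `CCCCCCCCCC(=O)NCC(C)(C)CC1=C(O)C(=O)c2ccccc2C1=O` gives 15000 nM, and compound 3 `CCCCCCCCCCCCCC(=O)NCC(C)(C)CC1=C(O)C(=O)c2ccccc2C1=O` gives 9810 nM. The step of a 1.2-fold lower number from compound 1 to compound 2 (0.09 log units; within the scatter) comes from the change (ethyl in place of hydrogen on a saturated chain carbon, seven bonds along the chain from a carbonyl carbon). Compound 3 differs from compound 1 by hexyl in place of hydrogen on a saturated chain carbon, seven bonds along the chain from a carbonyl carbon, and the step of a 1.9-fold lower number from compound 1 to compound 3 (0.27 log units; within the scatter) stays within the scatter, as does a 1.5-fold lower number from compound 2 to compound 3 (0.18 log units; within the scatter). Compound 4 `CCCCCCCCCCCCCCCC(=O)NCC(C)(C)CC1=C(O)C(=O)c2ccccc2C1=O` has not yet been measured. It differs from compound 3 by ethyl in place of hydrogen on a saturated chain carbon, ten or more bonds along the chain from a carbonyl carbon, the same kind of change as that from compound 1 to compound 2, though at a different place. Because a 1.2-fold lower number from compound 1 to compound 2 (0.09 log units; within the scatter) was small, a similarly small step a 1.2-fold lower number from compound 3 to compound 4 (0.09 log units; within the scatter) is expected. Compound 4 is estimated at 8000 nM.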

Compound 4, half-maximal inhibitory concentration: 5600 nM
Beside the measured number, compound 4's estimate is 1.4-fold (0.15 log units) above it; the range from low to high includes it.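

In this assay the ethyl change gives steps that agree at its two places along the chain: the same change on two cores in this assay, a 1.2-fold lower number (0.09 log units; within the scatter) from compound 1 to compound 2 and a 1.8-fold lower number (0.24 log units; within the scatter) from compound 3 to compound 4, 1.4-fold (0.15 log units) apart, within the scatter of two such steps
The hexyl change agrees in the same way: the same change on two cores in this assay, a 1.9-fold lower number (0.27 log units; within the scatter) from compound 1 to compound 3 and a 2.7-fold lower number (0.43 log units; beyond the scatter) from compound 2 to compound 4, 1.4-fold (0.15 log units) apart, within the scatter of two such steps
The steps of a 2.7-fold lower number from compound 2 to compound 4 (0.43 log units; beyond the scatter) and a 3.3-fold lower number from compound 1 to compound 4 (0.52 log units; beyond the scatter) pass beyond the scatter and a 1.8-fold lower number from compound 3 to compound 4 (0.24 log units; within the scatter) stays within it, yet these amides differ only in chain length and share one assay, so nothing here shows that the changes would carry over to an unrelated core. On these data alone, whether the numbers keep moving with a chain longer than that of compound 4 remains open. So does what an amine or a carboxylic acid at the end of the chain would give.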